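Replacing 4-cyanophenyl with pyridin-4-yl

The source may hold more compounds than are shown below. What is called first, only, known or untested is meant among the compounds shown, and "the series" means these compounds.

Of the compounds shown here, three sharing one core have been measured in a physicochemical assay for solubility, read by HPLC; a higher number here means a more soluble compound, a lower number a less soluble compound. Compound 1 `COc1ccc(NC[C@@H](O)COc2ccc(N3C[C@H](CNC(C)=O)OC3=O)cc2F)cc1` gives 1300 nM, compound 2 `CC(=O)NC[C@H]1CN(c2ccc(OC[C@H](O)CNc3ccccc3)c(F)c2)C(=O)O1` gives 296000 nM, and compound 3 `CC(=O)NC[C@H]1CN(c2ccc(OC[C@H](O)CNc3ccc(C#N)cc3)c(F)c2)C(=O)O1` gives 69000 nM, the second highest of the three numbers. The next structure, compound 4 `CC(=O)NC[C@H]1CN(c2ccc(OC[C@H](O)CNc3ccncc3)c(F)c2)C(=O)O1`, has pyridin-4-yl in place of 4-cyanophenyl on an amine nitrogen.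

Three measured steps alter the same aromatic ring. Two are large: hydrogen in place of methoxy gives a 230-fold higher number from compound 1 to compound 2 (2.36 log units; beyond the scatter), and cyano in place of methoxy gives a 53-fold higher number from compound 1 to compound 3 (1.72 log units; beyond the scatter). The closest guide is the modest step for cyano in place of hydrogen, a 4.3-fold lower number from compound 2 to compound 3 (0.63 log units; beyond the scatter). For the measured compounds named here, compound 4 also has no cyano group, so a modest rise in this assay is expected, although no measured compound carries pyridin-4-yl. The expected step is a 3.6-fold higher number from compound 3 to compound 4 (0.56 log units; beyond the scatter). For compound 4 the estimated value is 250000 nM, with an expected range from 70000 nM to 900000 nM.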

Compound 4, solubility: 24600000 nM
Beside the measured number, compound 4's estimate is 98-fold (1.99 log units) below it, outside the stated range (above it).
By their numbers in this assay, from the lowest: compound 1; then compound 3; then compound 2; then compound 4.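

For the compounds shown here, at this position on the amine nitrogen, the earlier steps changed only a group on a carbon-only ring, whereas changing the ring itself to pyridin-4-yl moves the number in this assay a long way (a 360-fold higher number from compound 3 to compound 4 (2.55 log units; beyond the scatter)). Removing the nitrile cannot account for all of this, since compound 2 also has no nitrile and the ring change alone still gives a large rise (an 83-fold higher number from compound 2 to compound 4 (1.92 log units; beyond the scatter)); the step from the methoxy compound is the widest in the set (a 19000-fold higher number from compound 1 to compound 4 (4.28 log units; beyond the scatter)). Nothing measured here explains why the pyridin-4-yl compound stands so far above the others.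

As far as these compounds go, whether an amine or a carboxylic acid on the phenyl ring could give a rise of similar size remains open. So does whether a pyridin-4-yl ring carrying a methoxy group would keep the high number.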